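Acid to methyl ketone on the side chain of compound 2

The source may hold more compounds than are shown below. What is called first, only, known or untested is meant among the compounds shown, and "the series" means these compounds.

Measured so far:
compound 1 `COC(=O)CCCc1onc(NS(=O)(=O)c2ccc(C(C)(C)C)cc2)c1Sc1cccc(OC)c1`: 400 nM in an assay on A7R5 cells for displacement of a labelled ligand from Endothelin-1 receptor (Rattus norvegicus); on this read-out higher numbers stand for weaker inhibition and lower numbers for stronger inhibition
compound 2 `COc1cccc(Sc2c(NS(=O)(=O)c3ccc(C(C)(C)C)cc3)noc2CCCC(=O)O)c1`: 4300 nM in this assay

Among the measured compounds shown here, compound 2 holds the higher of the two numbers; the single measured step, an 11-fold higher number from compound 1 to compound 2 (1.03 log units; beyond the scatter), separates it from compound 1. Compound 3 `COc1cccc(Sc2c(NS(=O)(=O)c3ccc(C(C)(C)C)cc3)noc2CCCC(C)=O)c1` carries methyl in place of hydroxy on a carbonyl carbon, read one bond further out as carboxy to acetyl. The measured step bears directly on this change, since the hydroxy that leaves is the very group that arrives in the step from compound 1 to compound 2. A move of comparable size in the opposite direction is therefore expected, a 6.1-fold lower number from compound 2 to compound 3 (0.79 log units; beyond the scatter). Compound 3 is estimated at 700 nM, within 250 nM to 2500 nM.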

Compound 3, half-maximal inhibitory concentration: 1300 nM
Estimate against measurement, compound 3: 1.9-fold (0.27 log units) below, within the range that was stated.
By their numbers in this assay, from the lowest: compound 1; then compound 3; then compound 2.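

In this assay, methyl in place of hydroxy on a carbonyl carbon gives a 3.3-fold lower number from compound 2 to compound 3 (0.52 log units; beyond the scatter) and so the stronger inhibition on this side chain is not confined to the methyl ester. Methyl in place of methoxy on the same carbonyl carbon gives a 3.3-fold higher number from compound 1 to compound 3 (0.51 log units; beyond the scatter) and places the acetyl end between the other two ends, with each step beyond the scatter. No measured evidence accounts for this order.

As far as these compounds go, whether an amide, a primary alcohol or a longer chain would fit this order remains open. From the compounds shown here alone, whether the order holds with other groups on the shared core also remains open.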